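A few compounds are considered here, and "the series" means these few. Any claim that something is new, unique, unknown or untested is made for them only; others in the source may bear on it.

The compounds share one core, with a chloro-substituted aryl ring held on a heterocycle that is joined to an amide-type nitrogen in a ring; they differ only in the group on the carbonyl carbon. For the measured compounds named here, compound 3 `O=C(N1CCCCCC1)N1CC(c2nc(-c3cccc(Cl)c3)no2)C1` carries azepan-1-yl there, and in an assay on HEK293 cells for positive allosteric modulation of metabotropic glutamate receptor 5 (Homo sapiens), read by FLIPR (on this read-out lower numbers stand for an effect already at smaller amounts and higher numbers for an effect only at larger amounts of compound), compound 3 gives 47 nM, the only number in the set. Compound 1 `COC1CCN(C(=O)N2CC(c3nc(-c4cccc(Cl)c4)no3)C2)CC1` carries 4-methoxypiperidin-1-yl, and in this assay compound 1 reaches only the limit > 10000 nM. Compound 2 `COC1CCCN(C(=O)N2CC(c3nc(-c4cccc(Cl)c4)no3)C2)C1` carries 3-methoxypiperidin-1-yl, and in this assay compound 2 likewise reaches only the limit > 10000 nM. The step that the two limits leave unreadable from compound 1 to compound 2, since both values sit at the limit of > 10000 nM in this assay, at which 2 of the 3 values shown sit. The steps of an at least 210-fold lower number from compound 1 to compound 3 (2.32 log units; beyond the scatter) and an at least 210-fold lower number from compound 2 to compound 3 (2.32 log units; beyond the scatter) show how much is lost when a methoxy-bearing piperidine stands in place of azepane. Compound 4 `CC1CN(C(=O)N2CC(c3nc(-c4cccc(Cl)c4)no3)C2)CC(C)O1` is not yet measured; it differs from compound 3 in that (2,6-dimethylmorpholin-4-yl in place of azepan-1-yl on a carbonyl carbon). Going by the values given here, the entering group brings one hydrogen-bond acceptor where azepan-1-yl has none, as the two methoxypiperidines do, but no measured step covers this exact exchange. Compound 4 is therefore expected to give about 1500 nM, somewhere between 200 nM and 10000 nM. That estimate means the step of a 32-fold higher number from compound 3 to compound 4 (1.50 log units; beyond the scatter) is expected, with a fair chance that only a limit is reported.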

Compound 4, half-maximal effective concentration: > 10000 nM
Compound 4: a limit, no number (the forecaster's own chance of this, stated with the estimate: 35%); middle value at least 6.6-fold (0.82 log units) away from the limit.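

Putting 2,6-dimethylmorpholin-4-yl in place of azepan-1-yl on the carbonyl carbon brings an at least 210-fold higher number from compound 3 to compound 4 (2.32 log units; beyond the scatter) in this assay, so the large loss seen with the two methoxypiperidines also appears when the oxygen sits in the ring itself and not on a methoxy group. Of the four groups shown on this carbonyl carbon, only azepan-1-yl, the one without oxygen, gives a number, while all three oxygen-bearing groups end at the same assay limit and no order among them can be read, as the steps that link compounds 1, 2 and 4 cannot be read: the limit of > 10000 nM in this assay, at which 3 of the 4 values shown sit.

The exchange from compound 3 to compound 4 alters ring size, adds a ring oxygen and adds two methyl groups all at once, so the compounds shown do not tell which of these changes matters, nor whether the oxygen is responsible at all. Plain piperidin-1-yl, which has six ring members and no oxygen, would separate ring size from the oxygen, and 2,6-dimethylpiperidin-1-yl would do the same with the two methyl groups kept in place.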